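The source may hold more compounds than are shown below. What is called first, only, known or untested is meant among the compounds shown, and "the series" means these compounds.

Compound 1 `CCN(CC)CN1C(=O)/C(=N/NC(=S)Nc2ccccc2)c2cc(Cl)ccc21` gives 3000 nM.
Compound 2 `CCN(CC)CN1C(=O)/C(=N/NC(=S)Nc2ccc(OC)cc2)c2ccccc21` gives 9200 nM.

In an ADME assay on MDCK cells (Canis lupus familiaris) for cytotoxicity (a lower number here means that less compound is tolerated, a higher number that more compound is tolerated), compound 1 has the lower number of the two, and compound 2 stands higher by more than the usual scatter. Compound 3 `CCN(CC)CN1C(=O)/C(=N/NC(=S)Nc2ccccc2)c2ccccc21` differs from compound 1 in one place (hydrogen in place of chloro on an aromatic carbon), with hydrogen in place of chloro on an aromatic carbon. Within the data shown here, no measured pair shows this change alone. Compound 2 also lacks the chloro and gives 9200 nM in this assay, so a modest rise is expected. The estimated change a 2.0-fold higher number from compound 1 to compound 3 (0.30 log units; within the scatter) is small and upward. Compound 3 is expected at 6000 nM within a range of 2500 nM to 15000 nM as a working estimate.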

Compound 3, half-maximal cytotoxic concentration: 1600 nM
Compound 3: middle estimate off by 3.8-fold (0.57 log units), on the high side; measured number below the stated range.
By their numbers in this assay, from the lowest: compounds 3 and 1 (each within the scatter of the next); then compound 2.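

In this assay, hydrogen in place of chloro on this aromatic carbon gives a 1.9-fold lower number from compound 1 to compound 3 (0.27 log units; within the scatter) and so shows no clear sensitivity to this change at this position. Hydrogen in place of methoxy matters more, with a 5.8-fold lower number from compound 2 to compound 3 (0.76 log units; beyond the scatter) as the larger step, so in these compounds the methoxy counts for more than the chloro. Nothing available explains either step.

From the compounds shown here alone, it remains open whether a fluoro, a nitrile or an amine on this same carbon would match chloro and hydrogen. Going by these compounds, whether methoxy would have the same effect alongside chloro is also open.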